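A few compounds are considered here, and "the series" means these few. Any claim that something is new, unique, unknown or untested is made for them only; others in the source may bear on it.

Measured compounds in a functional assay on BGC-823 cells (Homo sapiens) for cytotoxicity, read by CCK-8 assay, with a stated time of 24 h; on this read-out lower numbers stand for stronger inhibition and higher numbers for weaker inhibition:
Compound 1 `C/C(=C\c1cc(-c2ccccc2)cs1)C(N)=O`; in this assay compound 1 reports the limit > 50000 nM.
Compound 2 `C/C(=C\c1cccc(-c2ccccc2)c1)C(N)=O`; in this assay compound 2 reports the limit > 50000 nM.
Compound 3 `C/C(=C\c1cc(-c2ccccc2C)cs1)C(N)=O`; in this assay compound 3 reports the limit > 50000 nM.

Compound 1 stands at the limit of this assay; no number is known for it. The same holds for compound 2 and for compound 3, so that all three values shown sit at the limit of > 50000 nM in this assay, at which 3 of the 3 values shown sit. Within the data shown here, the one step that touches compound 1, a step that the two limits leave unreadable from compound 1 to compound 3, is not readable, since both ends are limits; the change there is methyl in place of hydrogen on an aromatic carbon.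

Compound 4 `C/C(=C\c1cc(-c2ccc([N+](=O)[O-])cc2)cs1)C(N)=O` differs from compound 1 by nitro in place of hydrogen on an aromatic carbon, the carbon sitting on a six-membered aromatic ring of carbon only, para to a large group. Among the measured compounds shown here, no measured step bears on this change in a readable way; the pair from compound 1 to compound 3 shows only that a substituent on that ring has not brought a value into the measurable range.

On this basis compound 4 is expected to remain at or near the limit of this assay, with an estimated step that the limit leaves unreadable from compound 1 to compound 4 that is not expected to exceed the scatter. The estimate for compound 4 is 60000 nM, within 15000 nM to 250000 nM.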

Compound 4, half-maximal inhibitory concentration: > 50000 nM
Compound 4 was reported as a limit (the forecaster's own chance of this, stated with the estimate: 75%); the middle value does not contradict the limit.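

In this assay compound 4 reports > 50000 nM, which is a limit and not a number. Compound 1 is also a limit, so the step to compound 4 cannot be read, and the series stays where it was: the limit of > 50000 nM in this assay, at which 4 of the 4 values shown sit.

The compounds shown leave open whether any change to the shared core brings a value into the measurable range.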